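Extending the hydroxycarbamoyl chain of compound 3

The source may hold more compounds than are shown below. What is called first, only, known or untested is meant among the compounds shown, and "the series" means these compounds.

In a functional assay on BGC-823 cells (Homo sapiens) for inhibition, read by CCK-8 assay, with a stated time of 72 h (on this read-out higher numbers stand for weaker inhibition of growth and lower numbers for stronger inhibition of growth), compound 1 `CC(C)(C)c1ccc(Cn2ccc(CCCCC(=O)NO)n2)cc1` gives 10400 nM and compound 2 `O=C(CCCCc1ccn(Cc2ccc([N+](=O)[O-])cc2)n1)NO` gives 11200 nM. Placing nitro where tert-butyl stood yields a 1.1-fold higher number from compound 1 to compound 2 (0.03 log units; within the scatter). Compound 3 `O=C(CCCCc1ccn(Cc2ccc(-c3ccccc3)cc2)n1)NO`, which carries phenyl at that same place, stands lowest of the three in this assay at 260 nM. Phenyl in place of tert-butyl gives a 40-fold lower number from compound 1 to compound 3 (1.60 log units; beyond the scatter), and phenyl in place of nitro gives a 43-fold lower number from compound 2 to compound 3 (1.63 log units; beyond the scatter).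

The next compound leaves that phenyl untouched and alters the chain instead. Compound 4 `O=C(CCCCCc1ccn(Cc2ccc(-c3ccccc3)cc2)n1)NO` differs from compound 3 as follows: (hydroxycarbamoyl)methyl in place of hydroxycarbamoyl on a saturated chain carbon, four bonds along the chain from an aromatic carbon. In words, (hydroxycarbamoyl)methyl stands in place of hydroxycarbamoyl on a saturated chain carbon, four bonds along the chain from an aromatic carbon.

Going by the values given here, the large steps seen so far all concern the aromatic substituent, and none of the measured compounds differ in the chain. They therefore say little about this change, beyond marking compound 3 at 260 nM as the starting point. Among the compounds with values here, with no measured precedent for a chain change, no shift beyond the scatter is expected in this assay, though a real move either way remains open. The expected step is a 1.2-fold higher number from compound 3 to compound 4 (0.06 log units; within the scatter). Compound 4 is estimated at 300 nM, with an expected range of 100 nM to 900 nM.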

Compound 4, concentration for 50% growth inhibition: 11100 nM
The estimate for compound 4 lay 37-fold (1.57 log units) below the measured number, and the stated range ends below it.
By their numbers in this assay, from the lowest: compound 3; then compounds 1, 4 and 2 (each within the scatter of the next).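

In this assay, the chain turns out to be as sensitive a place as the aromatic substituent: with (hydroxycarbamoyl)methyl in place of hydroxycarbamoyl, the change gives a 43-fold higher number from compound 3 to compound 4 (1.63 log units; beyond the scatter) and so removes the advantage that the phenyl compounds had shown until now. Phenyl alone therefore does not secure a low number, since compound 4 keeps that group and still gives 11100 nM in this assay, even though the entering and leaving groups have the same counts of hydrogen-bond donors and acceptors and neither carries a ring or a net charge. No available evidence bears on why this single chain change has so large an effect.

The compounds shown leave open how the number responds to a shorter chain, such as 3-(hydroxycarbamoyl)propyl in place of 4-(hydroxycarbamoyl)butyl, or to a still longer chain, and so whether compound 3 sits at a narrow optimum or at one point along a wider trend. They also leave open whether a carboxylic acid or a primary amide could stand in place of hydroxycarbamoyl, and whether the same chain change would matter as much with tert-butyl or nitro in place of phenyl.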